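Shifting the amine within the side chain of compound 2

The source may report more compounds than this note shows. Statements on the series, on what has been measured and on what is new or still open speak of the compounds shown alone.

Compound 1 `CC(=O)N1C[C@@H](C(=O)N2CCN(c3ccc(C)cc3[C@@H](NC(=O)CCN(C)C)C(C)C)CC2)[C@H](c2ccc(Cl)cc2)C1`: 100%
Compound 2 `CNCC(=O)N[C@H](c1cc(C)ccc1N1CCN(C(=O)[C@@H]2CN(C3CCOCC3)C[C@H]2c2ccc(Cl)cc2)CC1)C(C)C`: 84%
Compound 3 `Cc1ccc(N2CCN(C(=O)[C@@H]3CNC[C@H]3c3ccc(Cl)cc3)CC2)c([C@@H](NC(=O)CCN(C)C)C(C)C)c1`: 72%

In a functional assay on CHO cells with Melanocortin receptor 4 (Homo sapiens) as the target, read by cAMP accumulation (on this read-out lower numbers stand for smaller maximal responses and higher numbers for larger maximal responses), compound 1 reaches the top of the three numbers. Compound 2 stands second highest; its gap to compound 3, the nearest, and its gap to compound 1, the furthest, both lie beyond the usual scatter of this measurement, so its place between the other two is a real one and not noise.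

Compound 4 `Cc1ccc(N2CCN(C(=O)[C@@H]3CN(C4CCOCC4)C[C@H]3c3ccc(Cl)cc3)CC2)c([C@@H](NC(=O)CCN)C(C)C)c1` has not yet been measured. It keeps every atom of compound 2 but joins them differently: aminomethyl in place of methylamino on a saturated chain carbon bound to a carbonyl carbon. The chain still carries one hydrogen-bond donor and one acceptor, and no ring is gained or lost.

Going by the values given here, the only step measured so far, a number 28 percentage points lower from compound 1 to compound 3 (beyond the scatter), concerns the acetyl on a ring nitrogen in the shared core, a different place from the side chain changed here, and it does not map onto the present change. Among the compounds with values here, no measured pair shows what rearranging this chain does. With nothing to argue for a shift in either direction, a step within the scatter is expected: a number 2 percentage points lower from compound 2 to compound 4 (within the scatter). Compound 4 is therefore estimated at 82%, with a range from 65% to 100%.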

Compound 4, intrinsic activity: the largest response reached, in percent of the reference agonist's: 107%
Compound 4: the middle estimate sits 25 percentage points below what was measured, and the stated range ends below it.
By their numbers in this assay, from the lowest: compound 3; then compound 2; then compounds 1 and 4 (each within the scatter of the next).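

This side chain is not a silent place on the molecule: in this assay, the rearrangement gives a number 23 percentage points higher from compound 2 to compound 4 (beyond the scatter), even though methylamino and aminomethyl have the same heavy atoms, the same hydrogen-bond donor and acceptor counts, no ring and no net charge. These counts therefore do not capture the difference that matters here; how the same atoms are joined does, and read one bond further out, the change is (methylamino)methyl to 2-aminoethyl. No measurement shown here explains the shift in maximal response.

The compounds shown leave open whether the higher number goes with the longer 2-aminoethyl chain or with the loss of the methyl group from the nitrogen, since this single pair changes both at once. A 2-(methylamino)ethyl group at the same place would keep the longer chain and the methyl group together, while a 3-aminopropyl chain would show whether lengthening the chain further has any effect on the response.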